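Chloro Added to the Urea Terminal Ring of Compound 1

The compounds below may be only part of what the source reports. "The series", "measured", "known", "first", "only" and "open" are said of these compounds alone.

Compound 1 `O=C(Nc1cccc(-n2cc(-c3ccncc3)c(-c3ccc(Cl)c(O)c3)n2)c1)Nc1cccc(C(F)(F)F)c1` reaches only a limit in a functional assay on NCI-H522 cells (Homo sapiens) for inhibition, read by sulforhodamine B assay, with a stated time of 48 h; a higher number here means that more compound is tolerated, a lower number that less compound is tolerated: compound 1 reads > 32500 nM. Compound 3 `COc1cc(-c2nn(-c3cccc(NC(=O)Nc4cccc(C(F)(F)F)c4)c3)cc2-c2ccncc2)ccc1Cl` likewise sits at a limit, giving > 50000 nM. Compound 2 `COc1cc(-c2nn(-c3cccc(NC(=O)Nc4cc(C(F)(F)F)cc(C(F)(F)F)c4)c3)cc2-c2ccncc2)ccc1Cl` gives a number, 6560 nM. The comparison of methyl and hydrogen on the oxygen is a step that the two limits leave unreadable from compound 1 to compound 3. Removing a trifluoromethyl from the terminal ring gives an at least 7.6-fold higher number from compound 2 to compound 3 (0.88 log units; beyond the scatter), so a substituent on that ring can lower the number in this assay beyond the scatter. Compound 4 `O=C(Nc1cccc(-n2cc(-c3ccncc3)c(-c3ccc(Cl)c(O)c3)n2)c1)Nc1ccc(Cl)c(C(F)(F)F)c1` differs from compound 1 by chloro in place of hydrogen on an aromatic carbon. For the measured compounds named here, that substituent step is the only readable guide, so compound 4 is expected to give a lower number, estimated at 15000 nM with a range of 4000 nM to 50000 nM, an expected step of an at least 2.1-fold lower number from compound 1 to compound 4 (0.33 log units; beyond the scatter).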

Compound 4, concentration lethal to 50% of the cells: 24500 nM
Compound 4: the middle estimate sits 1.6-fold (0.21 log units) below what was measured; the measured number falls inside the stated range.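

In this assay, chloro para to a large group and ortho to a trifluoromethyl group gives an at least 1.3-fold lower number from compound 1 to compound 4 (0.12 log units; that floor lies within the scatter). Compound 4 thus yields a number on a core where compound 1 yields only a limit. That limit gives the step a floor but no upper size, so the true effect of this change cannot be sized: the limit of > 32500 nM in this assay, at which 1 of the 4 values shown sits.

From the compounds shown here alone, whether chloro at this position would change the reading for compound 3 remains open. So does what an amine or a carboxylic acid there would give.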